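The compounds below may be only part of what the source reports. "The series", "measured", "known", "first", "only" and "open" are said of these compounds alone.

The measured compounds:
compound 1, `CCCCCCCCOC(=O)C(O)Cn1cnc2c(N)ncnc21`, with 100 ug/mL;
compound 2, `CCCCOC(=O)C(O)Cn1cnc2c(N)ncnc21`, with 200 ug/mL;
compound 3, `CCCCCOC(=O)C(O)Cn1cnc2c(N)ncnc21`, with 200 ug/mL.

All three values come from a functional assay on PRK cells (Oryctolagus cuniculus) for cytotoxicity; a higher number here means that more compound is tolerated, a lower number that less compound is tolerated. Compound 1 carries the lowest figure of the three, yet the steps to the other two, a 2.0-fold higher number from compound 1 to compound 2 (0.30 log units; within the scatter) and a 2.0-fold higher number from compound 1 to compound 3 (0.30 log units; within the scatter), lie within the scatter, and between the two shorter esters no change at the digits printed from compound 2 to compound 3 (within the scatter), so no order among the three can be read from these numbers.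

Compound 4, `CCOC(=O)C(O)Cn1cnc2c(N)ncnc21`, has not yet been measured in this assay. It differs from compound 1 in one place: hydrogen in place of hexyl on a saturated chain carbon, two bonds along the chain from an oxygen next to a carbonyl group. Within the data shown here, the steps that bear on this change are those from compound 1 to compound 2 and from compound 1 to compound 3, since each also shortens the same chain, and each moved the read-out in this assay only by an amount within the scatter, toward more compound tolerated. Cutting the chain down to ethyl goes further than any measured compound, and nothing shown says whether that small shift carries on or stops. Compound 4 is therefore expected to give a step of a 2.0-fold higher number from compound 1 to compound 4 (0.30 log units; within the scatter), within or barely beyond the scatter. The estimate for compound 4 in this assay is 200 ug/mL, expected to fall between 100 ug/mL and 400 ug/mL.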

Compound 4, minimum cytotoxic concentration: > 400 ug/mL
Compound 4: no number, only a limit; the forecaster's own chance of this, stated with the estimate: 10%; middle value at least 2.0-fold (0.30 log units) from the limit.
By their numbers in this assay, from the lowest: compounds 1, 2 and 3 (each within the scatter of the next). At a limit, above all of these: compound 4.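

Compound 4 gives no number in this assay, only a limit: the limit of > 400 ug/mL in this assay, at which 1 of the 4 values shown sits. Shortening the ester chain from octyl to ethyl gives an at least 4.0-fold higher number from compound 1 to compound 4 (0.60 log units; beyond the scatter), so this is the first change at this position that clears the scatter, which the smaller cuts to the chains of the earlier compounds did not do. The other two steps, an at least 2.0-fold higher number from compound 3 to compound 4 (0.30 log units; that floor lies within the scatter) and an at least 2.0-fold higher number from compound 2 to compound 4 (0.30 log units; that floor lies within the scatter), are floors only, so the limit does not yet set the ethyl ester clearly apart from either of those compounds, although a larger gap remains possible.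

The compounds shown leave open how much compound is tolerated beyond the limit for compound 4, and at which chain length the shift really sets in, as the intermediate chains cannot be told from octyl in this read-out. They also leave open whether a methyl ester, a chain longer than octyl or a carboxylic acid in place of the ester would continue the same trend, and they give no cause for the shift.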